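Swapping a halogen on the aryl ring of a triazole ether

The source may report more compounds than this note shows. Statements on the series, on what has been measured and on what is new or still open speak of the compounds shown alone.

This study measures how strongly each compound inhibits the growth of a colon-cancer cell line in a functional assay on HCT-116 cells (Homo sapiens) for cytotoxicity, read by MTT assay, with a stated time of 24 h; on this read-out lower numbers stand for stronger inhibition and higher numbers for weaker inhibition. Compound 1, with structure `COc1ccc(/C=C\C(=O)O)c(OCc2cn(-c3ccc(NC(=O)c4ccccc4)cc3)nn2)c1CC=C(C)C`, gives 16400 nM in this assay, a weak effect. Compound 2, with structure `COc1ccc(/C=C\C(=O)O)c(OCc2cn(-c3ccccc3F)nn2)c1CC=C(C)C`, carries a 2-fluorophenyl group on the triazole in place of the larger benzamide-bearing aryl group of compound 1, but in this assay compound 2 is recorded as "not determined" (no result reported), so compound 2 stands without a number. Compound 3, with structure `COc1ccc(/C=C\C(=O)O)c(OCc2cn(-c3ccccc3I)nn2)c1CC=C(C)C`, has not yet been measured. It differs from compound 2 by iodo in place of fluoro on an aromatic carbon. Among the compounds with values here, with no measured step available for this pair, the expected size of the move in this assay cannot be drawn from the data, and no direction beyond the scatter can be claimed. Compound 3 is therefore expected to lie near 15000 nM, with a plausible range from 4000 nM to 60000 nM.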

Compound 3, half-maximal inhibitory concentration: 23100 nM
Compound 3: middle estimate off by 1.5-fold (0.19 log units), on the low side; low and high end bracket the measured number.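

Compound 3 gives 23100 nM in this assay but compound 2 has no number to set beside it, so no step can be read between compound 2 and compound 3. On these data alone, what swapping fluoro for iodo does to this read-out stays open, and no outside evidence bears on the result.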